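The source may hold more compounds than are shown below. What is called first, only, known or untested is meant among the compounds shown, and "the series" means these compounds.

Working notes on the series. Three compounds share one core and differ only in the aryl group on the five-membered ring. Compound 1 `COc1cc(C(=O)c2sc(-c3ccc(Cl)cc3)cc2N)cc(OC)c1OC` gives 77 nM in a functional assay on MOLT-4 cells (Homo sapiens) for antiproliferative activity; a higher number here means a weaker inhibitor, a lower number a stronger inhibitor. Compound 2 `COc1cc(C(=O)c2sc(-c3ccc(F)cc3)cc2N)cc(OC)c1OC` gives 12 nM, and compound 3 `COc1cc(C(=O)c2sc(-c3ccc(Cl)c(Cl)c3)cc2N)cc(OC)c1OC` gives 270 nM. Compound 3 stands highest of the three; the nearest is compound 1, with a 3.5-fold higher number from compound 1 to compound 3 (0.54 log units; beyond the scatter) separating them, and the furthest is compound 2, with a 23-fold higher number from compound 2 to compound 3 (1.35 log units; beyond the scatter).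

Compound 4 `COc1cc(C(=O)c2sc(-c3ccccc3Cl)cc2N)cc(OC)c1OC` is not yet measured. Its change from compound 3: 2-chlorophenyl in place of 3,4-dichlorophenyl on an aromatic carbon. The step that bears most directly on it is a 3.5-fold higher number from compound 1 to compound 3 (0.54 log units; beyond the scatter), since that step added the second chloro which now leaves; the step of a 6.4-fold lower number from compound 1 to compound 2 (0.81 log units; beyond the scatter) shows that the halogen on this ring also matters. Going by the values given here, no measured pair speaks to where a single chloro sits. A modest step back toward the numbers of compound 1 is therefore expected, in the direction of a lower number, with a 2.7-fold lower number from compound 3 to compound 4 (0.43 log units; beyond the scatter). The estimate for compound 4 is 100 nM, in the range 30 nM to 400 nM.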

Compound 4, half-maximal inhibitory concentration: 17 nM
Compound 4: the middle estimate sits 5.9-fold (0.77 log units) above what was measured; the measured number lies below the stated range.
By their numbers in this assay, from the lowest: compounds 2 and 4 (each within the scatter of the next); then compound 1; then compound 3.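

Going by these compounds alone, the single chloro's placement matters: with one chloro on the ring in both compounds, 2-chlorophenyl in place of 4-chlorophenyl gives a 4.5-fold lower number from compound 1 to compound 4 (0.66 log units; beyond the scatter), the only pair here that speaks to where it sits. The change from 3,4-dichlorophenyl to 2-chlorophenyl gives a 16-fold lower number from compound 3 to compound 4 (1.20 log units; beyond the scatter), so the result at this carbon next to the ring sulfur cannot be read as loss of the second chloro alone. Two different halogenated phenyl groups also fall together here, with a 1.4-fold higher number from compound 2 to compound 4 (0.15 log units; within the scatter).

Nothing at hand accounts for these steps. Still open, going by these compounds, are whether a fluoro placed as the chloro is in compound 4 would behave alike, and whether a methoxy group or an amine on the phenyl ring would hold these numbers.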